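This account rests on a few compounds, and the source may have more. Where it says the series, first, only, none or still open, it means among the compounds named here.

compound 1 `COc1ccc(C2=NN(C(C)=O)C(c3cccc(OC)c3)O2)cc1`: 41000 nM
compound 2 `COc1ccc(C2=NN(C(C)=O)C(c3ccccc3OC)O2)cc1`: 5800 nM
compound 3 `COc1ccc(C2=NN(C(C)=O)C(c3cc(OC)ccc3OC)O2)cc1`: 500 nM

All three values come from a functional assay on L1210 cells (Mus musculus) for antiproliferative activity, read by MTT assay, with a stated time of 72 h; a lower number here means a stronger inhibitor, a higher number a weaker inhibitor. Compound 1 has the highest number of the three, which makes it the weakest inhibitor of the set. The closest neighbour is at a 7.1-fold lower number from compound 1 to compound 2 (0.85 log units; beyond the scatter).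

Compound 4 `COc1ccc(C2=NN(C(C)=O)C(c3cc(OC)cc(OC)c3)O2)cc1` has not been measured. It keeps the core of compound 1 and gains methoxy in place of hydrogen on an aromatic carbon, meta to a large group and meta to a methoxy group: methoxy in place of hydrogen on an aromatic carbon.

Two measured steps add a methoxy in the same way. Both are large, and both lower the number: an 82-fold lower number from compound 1 to compound 3 (1.91 log units; beyond the scatter) and a 12-fold lower number from compound 2 to compound 3 (1.06 log units; beyond the scatter). Both lead to compound 3, though, whose methoxy groups are placed differently from those of compound 4, so their full size may not carry over.

In this assay, the expected change is a smaller drop, a 6.8-fold lower number from compound 1 to compound 4 (0.83 log units; beyond the scatter). The estimate for compound 4 is 6000 nM, with an expected range of 1000 nM to 30000 nM.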

Compound 4, half-maximal inhibitory concentration: 500 nM
Estimate against measurement, compound 4: 12-fold (1.08 log units) above, and the stated range ends above it.
By their numbers in this assay, from the lowest: compounds 3 and 4 (each within the scatter of the next); then compound 2; then compound 1.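

In this assay, methoxy in place of hydrogen at this position, meta to a methoxy group, gives an 82-fold lower number from compound 1 to compound 4 (1.91 log units; beyond the scatter), so the change is as large here as at the place it takes in an 82-fold lower number from compound 1 to compound 3 (1.91 log units; beyond the scatter). Compound 3 and compound 4 end within the scatter of each other, so these two placements of the added methoxy cannot be told apart in this assay. The same added group therefore does not have one fixed size of effect across this series: the same change on two cores in this assay, a 12-fold lower number (1.06 log units; beyond the scatter) from compound 2 to compound 3 and an 82-fold lower number (1.91 log units; beyond the scatter) from compound 1 to compound 4, 7.1-fold (0.85 log units) apart, beyond the scatter of two such steps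

The compounds shown leave open whether methoxy itself is needed at this position, or whether a hydroxyl, a chlorine or a longer chain such as ethoxy would serve equally well. They also cannot show why the step differs in size between the two cores.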